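The source may report more compounds than this note shows. Statements on the series, on what has been measured and on what is new or still open speak of the compounds shown alone.

Measured in an in vitro assay on CHO cells for displacement of a labelled ligand from Bombesin receptor subtype-3 (Homo sapiens), read by scintillation counting, with a stated time of 2 h; a lower number here means a stronger inhibitor, a higher number a weaker inhibitor:
compound 1 `CCC(C)(C)Cc1c[nH]c(CCc2ccc(-c3cccc(C)n3)cc2)n1` gives 6.3 nM
compound 2 `CCC(C)(C)Cc1c[nH]c(CCc2ccc(-n3ccnn3)cc2)n1` gives 390 nM

Compound 1 stands lowest of the two numbers; its nearest neighbour is compound 2, reached by a 62-fold higher number from compound 1 to compound 2 (1.79 log units; beyond the scatter). Compound 3 `CCC(C)(C)Cc1c[nH]c(CCc2ccc(-c3csnn3)cc2)n1` is not yet measured; it differs from compound 1 as follows: 1,2,3-thiadiazol-4-yl in place of 6-methylpyridin-2-yl on an aromatic carbon. Within the data shown here, the one step that bears on this change is the one in which 1H-1,2,3-triazol-1-yl took the place of 6-methylpyridin-2-yl, and that step was large. A rise well beyond the scatter in this assay is therefore expected here too. Compound 3 is expected to give 120 nM (range 25 nM to 600 nM). The expected step is a 19-fold higher number from compound 1 to compound 3 (1.28 log units; beyond the scatter).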

Compound 3, half-maximal inhibitory concentration: 45 nM
Estimate against measurement, compound 3: 2.7-fold (0.43 log units) above, and the stated range covers the measured number.
By their numbers in this assay, from the lowest: compound 1; then compound 3; then compound 2.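

The loss at this position is not the same for every ring that replaces 6-methylpyridin-2-yl. 1,2,3-Thiadiazol-4-yl still gives a 7.1-fold higher number from compound 1 to compound 3 (0.85 log units; beyond the scatter) but, set against 1H-1,2,3-triazol-1-yl, it gives an 8.7-fold lower number from compound 2 to compound 3 (0.94 log units; beyond the scatter) and so keeps a good part of the binding that the triazolyl change lost. No measurement offered here accounts for the difference between these groups.

Open, as far as these compounds go, is whether the ring nitrogen or the methyl of compound 1 carries its lower number. A plain phenyl or pyridin-2-yl group at this place would separate the two.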